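Adding One Fluoro Where Only Limits Are Known

The source may report more compounds than this note shows. Statements on the series, on what has been measured and on what is new or still open speak of the compounds shown alone.

Compound 1 `COc1cc2ncnc(Nc3cc(O)[nH]n3)c2cc1OC` was tested in a functional assay on HCT-15 cells (Homo sapiens) for cytotoxicity, read by MTT assay (a higher number here means a weaker inhibitor, a lower number a stronger inhibitor), where compound 1 gives < 100000 nM, which is a limit and not a number. Compound 2 `COc1cc2ncnc(Nc3cc(-c4ccccc4)[nH]n3)c2cc1OC` gives < 100000 nM, and this too is only a limit. So far the record reads (the limit of < 100000 nM in this assay, at which 2 of the 2 values shown sit). Compound 2 therefore has no exact position on the scale of this assay.

Among the compounds with values here, the one measured step is a step that the two limits leave unreadable from compound 1 to compound 2, with phenyl in place of hydroxy on an aromatic carbon. It offers no size to carry forward.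

Compound 3 `COc1cc2ncnc(Nc3cc(-c4ccc(F)cc4)[nH]n3)c2cc1OC` differs from compound 2 in a single place: fluoro in place of hydrogen on an aromatic carbon. This is fluoro in place of hydrogen on an aromatic carbon, turning phenyl into 4-fluorophenyl. Within the data shown here, no measured step involves this change, so the data favour no direction, and no step beyond the usual scatter is expected in this assay. The expected step is a step that the limit leaves unreadable from compound 2 to compound 3. For compound 3 the estimate is 30000 nM, with an expected range from 5000 nM to 100000 nM, and another result given only as a limit would be no surprise.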

Compound 3, half-maximal inhibitory concentration: < 100000 nM
Compound 3 gave a limit, no number; the forecaster's own chance of this, stated with the estimate: 60%; the middle value is on the limit's open side.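

Within the data shown here, compound 3 gives only a limit, as do compound 1 and compound 2, so no step among the three can be read: the limit of < 100000 nM in this assay, at which 3 of the 3 values shown sit. The compounds shown leave open where each one sits on the scale of this assay, and whether fluoro in place of hydrogen makes any difference there.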